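The source may hold more compounds than are shown below. What is called first, only, known or untested is meant among the compounds shown, and "the series" means these compounds.

Compound 1 `CCOc1ccc(NCc2nc3cc(OC)ccc3[n+]([O-])c2-c2ccccc2)cc1` and compound 2 `COc1ccc2c(c1)[n+]([O-])c(C(=O)N=[N+]=[N-])c(C)[n+]2[O-]` have been run in a functional assay on Ehrlich cells (Mus musculus) for cytotoxicity, read by trypan blue exclusion, with a stated time of 2 h, tested at 100 ug/mL; on this read-out lower numbers stand for a stronger effect and higher numbers for a weaker effect at the one concentration tested. Compound 1 gives 85%. Compound 2 gives 56%, the lowest of the two numbers and beyond the scatter from compound 1. Within the data shown here, no step between measured compounds that differ in one place is available. Compound 3 `COc1ccc2c(c1)[n+]([O-])c(NC(=O)OC(C)C)c(C)[n+]2[O-]` differs from compound 2 in one place: a group of 7 heavy atoms (4 carbon, 1 nitrogen, 2 oxygen; no ring) in place of a group of 5 heavy atoms (1 carbon, 3 nitrogen, 1 oxygen; no ring), on an aromatic carbon An (isopropoxycarbonyl)amino group replaces the departing group on the same aromatic carbon. Among the measured compounds shown here, with no comparable step on record, a modest move toward a weaker effect is expected, a number 14 percentage points higher from compound 2 to compound 3 (beyond the scatter), in this assay. Compound 3 is estimated at 70%, between 45% and 95%.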

Compound 3, a percentage reported as activity, at one concentration (the size of the read-out at that concentration, not a potency): 87.7%
Compound 3: the middle estimate sits 17.7 percentage points below what was measured; the range from low to high includes it.
By their numbers in this assay, from the lowest: compound 2; then compounds 1 and 3 (each within the scatter of the next).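

In this assay, placing (isopropoxycarbonyl)amino on the aromatic carbon next to the ring nitrogen, in place of the group carried by compound 2, gives a number 31.7 percentage points higher from compound 2 to compound 3 (beyond the scatter). This first one-place comparison in the series shows that the effect at the one concentration tested depends on the group at this position, with the stronger effect belonging to compound 2. Nothing on hand identifies which feature of the exchange accounts for this step.

Still open, going by these compounds, is how an amine or a carboxylic acid on this carbon would compare with these two groups. Also open, on these data alone, is whether the step holds at other concentrations.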